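A methoxy step repeated on a second chalcone core

The compounds below may be only part of what the source reports. "The series", "measured", "known", "first", "only" and "open" are said of these compounds alone.

Three compounds sharing a fused bicyclic core were tested in a functional assay on DU-145 cells (Homo sapiens) for antiproliferative activity, read by MTT assay, with a stated time of 24 h; on this read-out lower numbers stand for stronger inhibition and higher numbers for weaker inhibition. Compound 1, `COc1ccc(-c2cc(C(=O)/C=C/c3ccccc3)nc3cc(-c4ccccc4)nn23)cc1OC`, gave 15600 nM in this assay. Compound 2, `COc1cc(-c2cc(C(=O)/C=C/c3ccccc3)nc3cc(-c4ccccc4)nn23)cc(OC)c1OC`, gave 16300 nM in this assay. Compound 3, `COc1ccc(-c2cc(/C=C/C(=O)c3ccc(C)cc3)nc3cc(-c4ccccc4)nn23)cc1OC`, gave 26800 nM in this assay. The difference between compound 1 and compound 2 is methoxy in place of hydrogen on an aromatic carbon and the step it made in this assay was a 1.0-fold higher number from compound 1 to compound 2 (0.02 log units; within the scatter). The two cores differ as follows: 2-((4-methylphenyl)carbonyl)ethenyl in place of (2-phenylethenyl)carbonyl on an aromatic carbon, and the step from compound 1 to compound 3 in this assay was a 1.7-fold higher number from compound 1 to compound 3 (0.24 log units; within the scatter).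

Compound 4, `COc1cc(-c2cc(/C=C/C(=O)c3ccc(C)cc3)nc3cc(-c4ccccc4)nn23)cc(OC)c1OC`, has not yet been measured in this assay. It differs from compound 3 by methoxy in place of hydrogen on an aromatic carbon. The place of this change is described in the same words as for the change from compound 1 to compound 2, so the two changes are taken as the same change, made once on the core of compound 1 and once on the core of compound 3.

The expectation for compound 4 rests on one measured example of the change, because the step of a 1.0-fold higher number from compound 1 to compound 2 (0.02 log units; within the scatter) stayed within the scatter. The step from compound 3 to compound 4 in this assay is therefore expected to be a 1.0-fold higher number from compound 3 to compound 4 (0.00 log units; within the scatter). For compound 4 in this assay the estimate is 27000 nM, with an expected range from 14000 nM to 52000 nM.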

Compound 4, half-maximal inhibitory concentration: 27100 nM
Compound 4: middle estimate off by 1.0-fold (0.00 log units), on the low side; the range from low to high includes it.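

In this assay, the methoxy that turns 3,4-dimethoxyphenyl into 3,4,5-trimethoxyphenyl gave a 1.0-fold higher number from compound 3 to compound 4 (0.00 log units; within the scatter) on the second core, and this step agrees with the one on the first core: the same change on two cores in this assay, a 1.0-fold higher number (0.02 log units; within the scatter) from compound 1 to compound 2 and a 1.0-fold higher number (0.00 log units; within the scatter) from compound 3 to compound 4, 1.0-fold (0.01 log units) apart, within the scatter of two such steps The exchange between the two cores, read on the 3,4,5-trimethoxyphenyl pair, gave a 1.7-fold higher number from compound 2 to compound 4 (0.22 log units; within the scatter), and it also agrees with its earlier counterpart: the same change on two cores in this assay, a 1.7-fold higher number (0.24 log units; within the scatter) from compound 1 to compound 3 and a 1.7-fold higher number (0.22 log units; within the scatter) from compound 2 to compound 4, 1.0-fold (0.01 log units) apart, within the scatter of two such steps Both changes therefore carried from one core to the other without a measurable gap in this series, but every step here lies within the scatter, so the agreement is one of near-zero steps and does not show that either change has a real effect that transfers, and it rests on only these four compounds in a single cell assay.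

The compounds shown leave open whether a step beyond the scatter would appear with a different group at the same place on the ring, such as a hydroxy group, an ethoxy group or an amine. They also leave open whether the agreement would hold on a third core, or with a carboxylic acid or an amine in place of the methyl group on the 4-methylphenyl ring.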